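Urea series: hydrogen in place of butyl

This account rests on a few compounds, and the source may have more. Where it says the series, first, only, none or still open, it means among the compounds named here.

Measured so far in a functional assay on RPMI-8226 cells (Homo sapiens) for inhibition; a higher number here means a weaker inhibitor, a lower number a stronger inhibitor:
compound 1 `CCOC(=O)CNC(=O)N1CC1C#N` gives 25000 nM
compound 2 `CCCCNC(=O)N1CC1C#N` gives 17000 nM
compound 3 `N#CC1CN1C(=O)Nc1ccc(Cl)cc1Cl` gives 4700 nM

Compound 2 stands with the second highest of the three numbers. Its nearest neighbour is compound 1, whose value lies within the scatter of that of compound 2, so no order between these two is claimed. Compound 3 is furthest from compound 2, with a lower number that is beyond the scatter.

Compound 4 `N#CC1CN1C(N)=O` differs from compound 2 by hydrogen in place of butyl on an amide-type nitrogen. Among the compounds with values here, no measured pair shows this change, so no step size can be read from the data. Within the data shown here, in all three measured compounds the amide-type nitrogen carries a substituent; compound 4 is the first with only hydrogen there. Among the measured compounds shown here, removing the butyl chain altogether is expected to move the number upward, toward weaker inhibition, probably beyond the scatter, though this rests on no measured step. Compound 4 is therefore estimated at 40000 nM in this assay, with a range of 15000 nM to 110000 nM. The expected step is a 2.4-fold higher number from compound 2 to compound 4 (0.37 log units; beyond the scatter).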

Compound 4, half-maximal inhibitory concentration: 288000 nM
Compound 4: middle estimate off by 7.2-fold (0.86 log units), on the low side; measured number outside the range, above it.
By their numbers in this assay, from the lowest: compound 3; then compounds 2 and 1 (each within the scatter of the next); then compound 4.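

In this assay, within the data shown here, hydrogen in place of butyl on the amide-type nitrogen gives a 17-fold higher number from compound 2 to compound 4 (1.23 log units; beyond the scatter) and is the first step that can be read at this position. The earlier compounds shown here all carry a substituent on that nitrogen and offered no such step, whereas this large change shows that the number depends strongly on what the nitrogen carries, at least for butyl against hydrogen. No evidence at hand bears on the reason for the size of this step.

The compounds shown leave open how the number runs with chain length: whether a methyl or propyl group on this nitrogen already recovers most of the step, or whether a longer chain such as octyl goes lower than butyl. Also open, as far as these compounds go, is whether a cyclohexyl ring in the same place would match butyl.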